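Compound 3 to compound 4: changing the amine

This account rests on a few compounds, and the source may have more. Where it says the series, first, only, none or still open, it means among the compounds named here.

Measured in a functional assay on the whole organism for agonist activity, with Mus musculus as the target; a higher number here means that more compound is needed for the effect, a lower number that less compound is needed:
- compound 1 `CCOC(=O)N(C)C(C)C#CCn1cncc1C`: > 100 mg/kg
- compound 2 `CN1CCN(CC#CCn2ccnc2)C1=O`: 0.97 mg/kg
- compound 3 `Cn1ccn(CC#CCN2CCCC2)c1=O`: 3.7 mg/kg

The entry for compound 1 is a limit of the assay, not a number. Of the two numerical values, compound 3 stands highest at 3.7 mg/kg, and the gap to compound 2 lies beyond the scatter.

Compound 4 `CN(C)CC#CCn1ccn(C)c1=O` carries dimethylamino in place of pyrrolidin-1-yl on a saturated chain carbon bound to a triple-bonded carbon. Going by the values given here, no measured step bears on this change. The expected step of a 1.6-fold higher number from compound 3 to compound 4 (0.21 log units; within the scatter) is small, within the scatter, and tilted towards a higher number in this assay. Compound 4 is estimated at 6 mg/kg, with an expected range of 2 mg/kg to 25 mg/kg.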

Compound 4, dose for half-maximal effect: 5.4 mg/kg
Compound 4: middle estimate off by 1.1-fold (0.05 log units), on the high side; low and high end bracket the measured number.
By their numbers in this assay, from the lowest: compound 2; then compounds 3 and 4 (each within the scatter of the next). At a limit, above all of these: compound 1.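

The series now has its first step at the saturated chain carbon bound to a triple-bonded carbon: in this assay, dimethylamino in place of pyrrolidin-1-yl gives a 1.5-fold higher number from compound 3 to compound 4 (0.16 log units; within the scatter). In this pair, the five-membered ring of pyrrolidin-1-yl is therefore not required for the effect. Nothing at hand ties this step to a property of either group.

As far as these compounds go, whether the same holds for a larger amine, such as piperidine or morpholine, remains open. Also open, from the compounds shown here alone, is whether this amine exchange reads the same on the core of compound 2.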